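The compounds below may be only part of what the source reports. "The series", "measured", "known", "first", "only" and "open" are said of these compounds alone.

Measured so far:
Compound 1 `CC1=CC[C@H](C(C)(C)NC(=S)NN)CC1`; in a functional assay on PC-3 cells (Homo sapiens) for inhibition, read by sulforhodamine B assay, with a stated time of 48 h (on this read-out higher numbers stand for weaker inhibition of growth and lower numbers for stronger inhibition of growth), compound 1 gives > 100000 nM, which is a limit of the assay rather than a number.
Compound 2 `CC1=CC[C@H](C(C)(C)NC(=S)N/N=C/c2ccco2)CC1`; in this assay compound 2 gives 27200 nM.

Going by the values given here, compound 2 therefore holds the only number; the remaining value is a limit (the limit of > 100000 nM in this assay, at which 1 of the 2 values shown sits). Among the compounds with values here, the single measured step, an at least 3.6-fold lower number from compound 1 to compound 2 (0.56 log units; beyond the scatter), moves the series off that limit and is the only quantitative anchor.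

Compound 3 `CC1=CC[C@H](C(C)(C)NC(=S)N/N=C/c2ccc[nH]2)CC1` is not yet measured. Its change from compound 2 is 1H-pyrrol-2-yl in place of furan-2-yl on a carbon with a double bond to nitrogen. Within the data shown here, no measured step touches the ring that hangs on the carbon with a double bond to nitrogen; the step from compound 1 to compound 2 installs that whole arylidene unit and says nothing about swapping one five-membered aromatic ring for another. With both rings matched in size and the hydrazone otherwise untouched, the expectation for compound 3 in this assay is a step of a 1.4-fold lower number from compound 2 to compound 3 (0.13 log units; within the scatter) that does not clearly exceed the scatter, leaning if anything slightly toward stronger inhibition. Compound 3 is thus estimated at 20000 nM, with a range from 7000 nM to 60000 nM.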

Compound 3, concentration for total growth inhibition: > 100000 nM
Compound 3 was reported as a limit; the forecaster's own chance of this, stated with the estimate: 10%; middle value at least 5.0-fold (0.69 log units) away from the limit.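

The ring on the carbon with a double bond to nitrogen is not a silent position in this assay: 1H-pyrrol-2-yl in place of furan-2-yl gives an at least 3.6-fold higher number from compound 2 to compound 3 (0.56 log units; beyond the scatter), so the arylidene unit alone does not account for the measurable growth inhibition. The two rings have the same heavy-atom count and differ in the hetero atom, with furan-2-yl counted at 0 hydrogen-bond donors and 1 hydrogen-bond acceptor and 1H-pyrrol-2-yl at 1 hydrogen-bond donor and 0 hydrogen-bond acceptors, but the series does not show which of these differences matters. The step between the two compounds that end at a limit cannot be read, since neither gives a number: the limit of > 100000 nM in this assay, at which 2 of the 3 values shown sit.

Still open, going by these compounds, is whether the oxygen of furan-2-yl itself is what counts, which a thiophen-2-yl ring or a phenyl ring on the same carbon would test. On these data alone, a methyl group on the pyrrole nitrogen would also show whether the hydrogen on that nitrogen goes with the loss, and the shared core remains untested in every other place.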